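Hydrazone series: hydroxy replacing chloro on the aryl ring

This account rests on a few compounds, and the source may have more. Where it says the series, first, only, none or still open, it means among the compounds named here.

Two members of this hydrazone series carry numbers in a functional assay on A549 cells (Homo sapiens) for cytotoxicity, read by XTT assay, with a stated time of 24 h; a higher number here means a weaker inhibitor, a lower number a stronger inhibitor. Compound 1 `Cn1nnnc1SCC(=O)N/N=C/c1ccccc1[N+](=O)[O-]` gives 1600000 nM. Compound 2 `Cn1nnnc1SCC(=O)N/N=C/c1ccccc1Cl` gives 6320000 nM, the highest of the two numbers shown; the only step so far, a 4.0-fold higher number from compound 1 to compound 2 (0.60 log units; beyond the scatter), is modest and lies beyond the scatter. The next member is compound 3 `Cn1nnnc1SCC(=O)N/N=C/c1ccccc1O`, which differs from compound 2 by hydroxy in place of chloro on an aromatic carbon. Within the data shown here, no measured step shows the consequence of a hydroxy entering at this position, so the sole step that bears on the question is the one from compound 1 to compound 2, and it bears only indirectly. Both the nitro and the chloro substituent have given weak inhibition in this assay, so a number of similar size is expected for compound 3, with wide uncertainty. The estimate for compound 3 is 4000000 nM, within 1000000 nM to 16000000 nM, meaning an expected step of a 1.6-fold lower number from compound 2 to compound 3 (0.20 log units; within the scatter).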

Compound 3, half-maximal inhibitory concentration: > 10000000 nM
Compound 3 ended at the assay's limit; the forecaster's own chance of this, stated with the estimate: 30%; middle value at least 2.5-fold (0.39 log units) away from the limit.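

In this assay compound 3 carries no number at this position on the aryl ring, ortho to a large group, only a limit: the limit of > 10000000 nM in this assay, at which 1 of the 3 values shown sits. Hydroxy in place of chloro gives an at least 1.5-fold higher number from compound 2 to compound 3 (0.19 log units; that floor lies within the scatter), so this change brings no gain in inhibition over chloro, though the size of the step cannot be read beyond that floor. Hydroxy in place of nitro gives an at least 6.2-fold higher number from compound 1 to compound 3 (0.79 log units; beyond the scatter), which leaves compound 1 the strongest of the three, with both of its steps beyond the scatter.

On these data alone, the true value of compound 3 stays open, and with it whether hydroxy and chloro differ by more than the scatter. As far as these compounds go, whether an amine, a methoxy group or a carboxylic acid at this position would come closer to nitro or fall with hydroxy also stays open.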